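Para halogen swap across two amide cores

The compounds below may be only part of what the source reports. "The series", "measured", "known", "first", "only" and "open" are said of these compounds alone.

Compound 1 `O=C(Nc1nnc(-c2ccc(F)cc2)s1)c1cc(Cl)ccc1O` and compound 2 `O=C(Nc1nnc(-c2ccc(Cl)cc2)s1)c1cc(Cl)ccc1O` share one core and differ only in one place: chloro in place of fluoro on an aromatic carbon. In a functional assay on MCF7 cells (Homo sapiens) for antiproliferative activity, read by MTT assay, with a stated time of 48 h (on this read-out lower numbers stand for stronger inhibition and higher numbers for weaker inhibition), compound 1 gives 750 nM, and in this assay compound 2 gives 450 nM; the step between them is a 1.7-fold lower number from compound 1 to compound 2 (0.22 log units; within the scatter), so the two numbers cannot be put in order. Compound 3 `O=C(Nc1nnc(-c2ccc(F)cc2)s1)c1ccccc1` carries a different core; how the two cores differ is not broken down here. In this assay compound 3 gives 5350 nM, the highest of the three numbers and beyond the scatter from both compound 1 and compound 2. Compound 4 `O=C(Nc1nnc(-c2ccc(Cl)cc2)s1)c1ccccc1` has not yet been measured. It stands to compound 3 as compound 2 stands to compound 1, the change being chloro in place of fluoro on an aromatic carbon at the same place, so it is the same kind of change on the other core. Among the compounds with values here, the step is expected to be small, a 1.5-fold lower number from compound 3 to compound 4 (0.18 log units; within the scatter), because a 1.7-fold lower number from compound 1 to compound 2 (0.22 log units; within the scatter) stayed within the scatter on the first core, and with only one precedent no larger effect can be assumed. Compound 4 is therefore estimated at 3500 nM in this assay, with a plausible range from 1500 nM to 8000 nM.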

Compound 4, half-maximal inhibitory concentration: 4850 nM
For compound 4 the middle estimate is 1.4-fold (0.14 log units) below the measured one; the measured number falls inside the stated range.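

Going from 4-fluorophenyl to 4-chlorophenyl on the core of compound 3 gives a 1.1-fold lower number from compound 3 to compound 4 (0.04 log units; within the scatter) in this assay and so these two numbers cannot be put in order. Set beside the same change on the core of compound 1, the step carries over with no difference that can be read: the same change on two cores in this assay, a 1.7-fold lower number (0.22 log units; within the scatter) from compound 1 to compound 2 and a 1.1-fold lower number (0.04 log units; within the scatter) from compound 3 to compound 4, 1.5-fold (0.18 log units) apart, within the scatter of two such steps. Within the data shown here, this shows only that the change stays small on both cores in this one read-out; with just two pairs, neither step beyond the scatter, it gives no direction for the change and does not show that the two halogens can be exchanged freely on other cores.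

Open, as far as these compounds go, is whether a group of another kind at the same place, such as methoxy, an amine or a carboxylic acid, would move the number beyond the scatter on either core. Also open, from the compounds shown here alone, is whether the change stays this small on any further core or in other cell lines.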